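Chloro in place of fluoro: notes on the series

The source may hold more compounds than are shown below. What is called first, only, known or untested is meant among the compounds shown, and "the series" means these compounds.

- compound 1 `Nc1nc(N)c2nc(CNc3ccc(C(=O)N[C@@H](CC(F)C(=O)O)C(=O)O)cc3F)cnc2n1` gives 0.0094 ug/mL
- compound 2 `CCCc1cc(C(=O)N[C@@H](CC(F)C(=O)O)C(=O)O)ccc1NCc1cnc2nc(N)nc(N)c2n1` gives 0.0053 ug/mL; 0.01 ug/mL (2 entries)

Within the data shown here, in a functional assay on cells (T-cell, Mus musculus) for inhibition (a lower number here means a stronger inhibitor, a higher number a weaker inhibitor), compound 1 stands at 0.0094 ug/mL, its only single number, and one further entry gives none. The repeat entries of compound 2 (the several entries of compound 2 in this assay, 0.0053 ug/mL; 0.01 ug/mL (2 entries)) lie within the scatter of that value. Compound 3 `Nc1nc(N)c2nc(CNc3ccc(C(=O)N[C@@H](CC(F)C(=O)O)C(=O)O)cc3Cl)cnc2n1` carries chloro in place of fluoro on an aromatic carbon. Among the measured compounds shown here, no measured step covers this change. With compound 2 at 0.0053 ug/mL; 0.01 ug/mL (2 entries), no large change is expected. The expected 1.1-fold higher number from compound 1 to compound 3 (0.03 log units; within the scatter) stays within the scatter, in no clear direction. For compound 3 the estimated value is 0.01 ug/mL, with an expected range from 0.004 ug/mL to 0.025 ug/mL.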

Compound 3, half-maximal inhibitory concentration: 0.0043 ug/mL
Estimate against measurement, compound 3: 2.3-fold (0.37 log units) above; measured number inside the range.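

Chloro in place of fluoro gives a 2.2-fold lower number from compound 1 to compound 3 (0.34 log units; beyond the scatter) in this assay, so this aromatic carbon, ortho to a large group, responds to the identity of the halogen, and chloro costs no inhibition here. The step is modest, and the spread between repeat entries within the series gives the yardstick for reading it: the several entries of compound 2 in this assay, 0.0053 ug/mL; 0.01 ug/mL (2 entries)

One pair of halogens does not make a trend. As far as these compounds go, whether bromo would continue the direction, and how a methyl or methoxy group would read on the same carbon, stays open.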